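The source may hold more compounds than are shown below. What is called first, only, known or untested is meant among the compounds shown, and "the series" means these compounds.

In a functional assay on ECa-109 cells for inhibition, with ECa-109 cell line (Homo sapiens) as the target, read by sulforhodamine B assay (a higher number here means a weaker inhibitor, a lower number a stronger inhibitor), compound 1 `COc1ccc(NC2=CC(=O)c3c(nc4n3[C@H]3OC[C@@H](O)[C@H]3OC4)C2=O)cc1` gives 3410 nM. Compound 2 `O=C1C(NC2CCCC2)=CC(=O)c2c1nc1n2[C@H]2OC[C@@H](O)[C@H]2OC1` carries cyclopentyl in place of 4-methoxyphenyl on an amine nitrogen. The step of an at least 4.6-fold higher number from compound 1 to compound 2 (0.67 log units; beyond the scatter) is a clear loss. For compound 2 this assay gives only a limit, > 16000 nM, which is the limit of > 16000 nM in this assay, at which 1 of the 2 values shown sits. Compound 3 `O=C1C(NC2CCCCC2)=CC(=O)c2c1nc1n2[C@H]2OC[C@@H](O)[C@H]2OC1` differs from compound 2 by cyclohexyl in place of cyclopentyl on an amine nitrogen. Among the measured compounds shown here, no measured step concerns such an exchange of one carbocycle for another, and the one step measured involves a different change. The expected step is a step that the limit leaves unreadable from compound 2 to compound 3, that is, nothing beyond the scatter. Compound 3 is therefore estimated at 20000 nM. For compound 3 the expected range runs from 8000 nM to 60000 nM.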

Compound 3, half-maximal inhibitory concentration: > 16000 nM
Compound 3: only a limit was reported; the forecaster's own chance of this, stated with the estimate: 70%; the middle value does not contradict the limit.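

Where the 4-methoxyphenyl gives way to cyclohexyl, the result is an at least 4.6-fold higher number from compound 1 to compound 3 (0.67 log units; beyond the scatter), so the loss seen with cyclopentyl is not confined to that one carbocycle. Compound 2 and compound 3 each give only a limit, and the step between them cannot be read. Two of the compounds now share this limit in this assay: the limit of > 16000 nM in this assay, at which 2 of the 3 values shown sit.

On these data alone, how a plain phenyl or a benzyl on the amine nitrogen would read stays open. So does whether the methoxy of compound 1 matters, or only its aromatic ring.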